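The source may hold more compounds than are shown below. What is called first, only, known or untested is meant among the compounds shown, and "the series" means these compounds.

Compounds measured in a physicochemical assay for acid dissociation, at 37 degrees C:

- compound 1 `CCCCNCc1cccnc1`: 8.66
- compound 2 `CCCNCc1cccnc1`: 8.38
- compound 3 `CN(C)Cc1cccnc1`: 7.76

Compound 2 stands within the scatter of compound 1, and its number lies above that of compound 3 by more than the scatter. Compound 4 `CCCN(CCC)Cc1cccnc1` follows from compound 2 by propyl in place of hydrogen on an amine nitrogen, which is propyl in place of hydrogen on an amine nitrogen.

For the measured compounds named here, the only measured step between compounds that differ in one place is a number 0.28 log units lower from compound 1 to compound 2 (within the scatter). It is hydrogen in place of methyl on a saturated chain carbon, so it leaves the amine nitrogen unchanged and bears on this change only indirectly. It does suggest that chain length alone need not move the number beyond the scatter.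

The closer guide is compound 3, which like compound 4 has no hydrogen on its amine nitrogen. However, compound 4 differs from compound 3 in its chains, so the value of compound 3, 7.76, marks a lower reference and not a direct prediction. A small move to a lower number is therefore expected in this assay, possibly no larger than the scatter. The expected step is a number 0.28 log units lower from compound 2 to compound 4 (within the scatter). For compound 4 the estimated value is 8.1, with an expected range from 7.7 to 8.5.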

Compound 4, acid dissociation constant: 8.13
For compound 4 the middle estimate is 0.03 log units below the measured one, and the stated range covers the measured number.
By their numbers in this assay, from the lowest: compound 3; then compounds 4, 2 and 1 (each within the scatter of the next, the first and the last beyond it).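

In this assay, for the compounds shown here, the result is a number 0.25 log units lower from compound 2 to compound 4 (within the scatter) and this is the first reading taken at the amine nitrogen itself, as the earlier step concerned a saturated chain carbon. It shows that propyl can take the place of hydrogen on this amine nitrogen, whose other neighbours are then two saturated chain carbons, without moving the number beyond the scatter, even though the hydrogen is lost from that nitrogen. No supporting information bears on what lies behind this step.

The compounds shown leave open whether a longer chain such as hexyl, a ring such as cyclohexyl, or a propyl chain carrying a carboxylic acid would also stay within the scatter at this amine nitrogen. Going by these compounds alone, with only one step read at this place, they also leave open whether propyl in place of hydrogen would give a similar result on the amine nitrogen of compound 1, which has the longer chain.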